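A few compounds are considered here, and "the series" means these few. Any claim that something is new, unique, unknown or untested is made for them only; others in the source may bear on it.

Working notes on the series. In an ADME assay on microsomes from liver (Homo sapiens) for metabolic stability (on this read-out lower numbers stand for a shorter-lived compound and higher numbers for a longer-lived compound), compound 1 (`CC#C[C@@H](Cc1nnn[nH]1)c1ccc(OCc2ccc3sc(F)c(-c4ccccc4C)c3c2)cc1`) gives 0.0667 h as the lowest of the two numbers available. Compound 2 (`CC#C[C@@H](Cc1nnn[nH]1)c1ccc(OCc2ccc3scc(-c4cc(OCCOC)ccc4C)c3c2)cc1`) gives 0.867 h and sits beyond the scatter from compound 1. Compound 3 (`CC#C[C@@H](Cc1nnn[nH]1)c1ccc(OCc2ccc3sc(C(F)(F)F)c(-c4ccc(OCCOC)cc4C)c3c2)cc1`) reads > 3 h and that reading is a limit of the assay, not a number. For the measured compounds named here, no two measured compounds differ in one place only, so the series offers no measured step to lean on.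

The next compound is compound 4 (`CC#C[C@@H](Cc1nnn[nH]1)c1ccc(OCc2ccc3sc(C)c(-c4ccccc4C)c3c2)cc1`), reached from compound 1 by methyl in place of fluoro on an aromatic carbon, next to the ring sulfur (methyl in place of fluoro on an aromatic carbon). The rest of the structure stays the same, so compound 1 at 0.0667 h is the only direct anchor for the expectation. Compound 2 and compound 3 differ from compound 1 in more than one place and give little guidance here. No shift beyond the scatter is expected in this assay and no firm direction can be given, so the estimated step (a 1.3-fold higher number from compound 1 to compound 4 (0.13 log units; within the scatter)) is expected to stay small. For compound 4 the estimate is 0.09 h with an expected range from 0.035 h to 0.25 h in this read-out.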

Compound 4, half-life: 0.0667 h
The estimate for compound 4 lay 1.3-fold (0.13 log units) above the measured number; the measured number falls inside the stated range.
By their numbers in this assay, from the lowest: compounds 1 and 4 (each within the scatter of the next); then compound 2. At a limit, above all of these: compound 3.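

In this assay the series now has its first step between compounds that differ in one place, and it reads no change at the digits printed from compound 1 to compound 4 (within the scatter) when fluoro gives way to methyl. On an aromatic carbon next to the ring sulfur, with the 2-methylphenyl group held in place, this exchange of one heavy atom for another therefore leaves the half-life unresolved from its starting point, something compound 2 and compound 3 could not show: each differs from compound 1 in more than one place, and steps to either of them cannot be read. Nothing measured here accounts for the absence of a change in this pair.

Still open, going by these compounds, is how this carbon responds to groups of a different kind, such as a nitrile, a carboxylic acid or an aminomethyl group, with the rest of compound 1 unchanged. Also open, on these data alone, is whether methyl and fluoro would read alike on the aryl groups of compound 2 and compound 3, whose longer ether chain has not been separated from the group at this carbon.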